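This account rests on a few compounds, and the source may have more. Where it says the series, first, only, none or still open, it means among the compounds named here.

Measured compounds:
Compound 1 `Cc1ncnc2c1c(I)cn2[C@@H]1O[C@H](CO)[C@@H](O)[C@H]1O` — in a functional assay on K562 cells (Homo sapiens), read by MTT assay, with a stated time of 72 h (a higher number here means a weaker inhibitor, a lower number a stronger inhibitor), compound 1 gives > 20000 nM, which is a limit of the assay.
Compound 2 `Cc1ncnc2c1c(-c1ccoc1)cn2[C@@H]1O[C@H](CO)[C@@H](O)[C@H]1O` — in this assay compound 2 gives > 20000 nM, also a limit of the assay.
Compound 3 `Cc1nc(N)c2c(I)cn([C@@H]3O[C@H](CO)[C@@H](O)[C@H]3O)c2n1` — in this assay compound 3 gives 1110 nM.

For the measured compounds named here, compound 3 thus carries the only number in the set; the other two values sit at a limit, as noted in the limit of > 20000 nM in this assay, at which 2 of the 3 values shown sit. The change from compound 1 to compound 2 is furan-3-yl in place of iodo on an aromatic carbon; the step it made is a step that the two limits leave unreadable from compound 1 to compound 2, so its size is not readable. Compound 4 `Cc1nc(N)c2c(-c3ccoc3)cn([C@@H]3O[C@H](CO)[C@@H](O)[C@H]3O)c2n1` is not yet measured and differs from compound 3 by furan-3-yl in place of iodo on an aromatic carbon, the same change at the same place. The difference between the core of compound 1 and the core of compound 3 is not broken down here. Going by the values given here, the expected step from compound 3 to compound 4 is a 1.4-fold higher number from compound 3 to compound 4 (0.13 log units; within the scatter), held near zero because the only measured instance of this change is a step that the two limits leave unreadable from compound 1 to compound 2 and gives no readable size. Compound 4 is therefore expected to give about 1500 nM, estimated between 400 nM and 6000 nM.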

Compound 4, half-maximal inhibitory concentration: > 20000 nM
Compound 4 was reported as a limit; the forecaster's own chance of this, stated with the estimate: 15%; at least 13-fold (1.12 log units) between middle value and limit.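

In this assay, furan-3-yl in place of iodo on the core of compound 3 gives an at least 18-fold higher number from compound 3 to compound 4 (1.25 log units; beyond the scatter), the only readable size for this change in the series. Compound 4 gives > 20000 nM, which is a limit of the assay. The same change on the core of compound 1 cannot be read, so the data show no number left after the change on either core but do not show that a step of one size carries from core to core: the limit of > 20000 nM in this assay, at which 3 of the 4 values shown sit.

Open, from the compounds shown here alone, is how a bromo, a methyl or an amine on this aromatic carbon of the core of compound 3 would read in this assay. Among the compounds shown, iodo is the only group on this carbon that comes with a number.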